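A Halogen Swap on the Aryl Group of Compound 1

The compounds below may be only part of what the source reports. "The series", "measured", "known", "first", "only" and "open" are said of these compounds alone.

Compound 1 `CCOC(=O)c1cnn(-c2nc(-c3ccccc3F)c(C#N)c(=O)n2C)c1N` was tested in a functional assay, with a stated time of 10 min (a lower number here means a stronger inhibitor, a higher number a weaker inhibitor), where compound 1 gives 86 ug/mL. Two other compounds were measured alongside it: compound 2 `Cn1c(NN)nc(-c2ccco2)c(C#N)c1=O` gives 58 ug/mL in this assay, and compound 3 `CSc1nc(-c2ccccc2Cl)c(C#N)c(=O)n1C` gives 67 ug/mL. Compound 1 has the highest of the three numbers, yet its gap to compound 3 and to compound 2 lies within the usual scatter, so nothing separates the three. Compound 4 `CCOC(=O)c1cnn(-c2nc(-c3ccc(Cl)cc3)c(C#N)c(=O)n2C)c1N` differs from compound 1 by one change: 4-chlorophenyl in place of 2-fluorophenyl on an aromatic carbon. For the measured compounds named here, no measured pair shows what such a swap does here, so the step is expected to stay within the scatter with no direction favored, and the expected step is a 1.1-fold lower number from compound 1 to compound 4 (0.03 log units; within the scatter). Compound 4 is estimated at 80 ug/mL in this assay, within a range of 35 ug/mL to 180 ug/mL.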

Compound 4, half-maximal inhibitory concentration: 94 ug/mL
The estimate for compound 4 lay 1.2-fold (0.07 log units) below the measured number; the range from low to high includes it.
By their numbers in this assay, from the lowest: compounds 2, 3, 1 and 4 (each within the scatter of the next).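

In this assay, for the compounds shown here, 4-chlorophenyl in place of 2-fluorophenyl on this aromatic carbon gives a 1.1-fold higher number from compound 1 to compound 4 (0.04 log units; within the scatter) and is the first step here that changes a single place. Across this pair, changing the halogen and its place on the phenyl ring together leaves the two compounds indistinguishable. No measurement bears on why this is so. On these data alone, whether an amine or a carboxylic acid in place of the halogen would carry the number beyond the scatter stays open. The compounds shown also leave open what an unsubstituted phenyl would give at this carbon.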